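A Phenylsulfanyl Group Replaces Pyrrolidin-1-yl on the Core

A few compounds are considered here, and "the series" means these few. Any claim that something is new, unique, unknown or untested is made for them only; others in the source may bear on it.

Three compounds share one core and have been measured in a functional assay on A549 cells (Homo sapiens) for cytotoxicity; on this read-out lower numbers stand for stronger inhibition and higher numbers for weaker inhibition:
Compound 1, `Cc1nn(C)c(-n2cccc2)c1/C=N/OCc1ccc(C(=O)OC(C)(C)C)cc1`, gives 1.64 ug/mL.
Compound 2, `Cc1nn(C)c(Oc2ccc(Cl)cc2)c1/C=N/OCc1ccc(C(=O)OC(C)(C)C)cc1`, gives 0.1 ug/mL.
Compound 3, `Cc1nn(C)c(N2CCCC2)c1/C=N/OCc1ccc(C(=O)OC(C)(C)C)cc1`, gives 0.13 ug/mL.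

Compound 3 stands second highest of these three numbers. Its nearest neighbour is compound 2: a 1.3-fold higher number from compound 2 to compound 3 (0.11 log units; within the scatter). Its furthest is compound 1: a 13-fold lower number from compound 1 to compound 3 (1.10 log units; beyond the scatter).

Compound 4, `Cc1nn(C)c(Sc2ccccc2)c1/C=N/OCc1ccc(C(=O)OC(C)(C)C)cc1`, has not yet been measured. It differs from compound 3 in one place: phenylsulfanyl in place of pyrrolidin-1-yl on an aromatic carbon. For the measured compounds named here, two measured steps bear on this. Replacing 1H-pyrrol-1-yl by 4-chlorophenoxy gave a 16-fold lower number from compound 1 to compound 2 (1.21 log units; beyond the scatter), and replacing it by pyrrolidin-1-yl gave a 13-fold lower number from compound 1 to compound 3 (1.10 log units; beyond the scatter). Both aryl-type and saturated-ring groups thus sit close together, and phenylsulfanyl is structurally closer to 4-chlorophenoxy than to pyrrolidin-1-yl, so no step beyond the scatter is expected. Compound 4 is estimated at 0.15 ug/mL, with a range from 0.05 ug/mL to 0.5 ug/mL. The expected step is a 1.2-fold higher number from compound 3 to compound 4 (0.06 log units; within the scatter).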

Compound 4, half-maximal inhibitory concentration: 0.13 ug/mL
Estimate against measurement, compound 4: 1.2-fold (0.06 log units) above, within the range that was stated.
By their numbers in this assay, from the lowest: compounds 2, 3 and 4 (each within the scatter of the next); then compound 1.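

In this assay, phenylsulfanyl on this aromatic carbon gives no change at the digits printed from compound 3 to compound 4 (within the scatter) against pyrrolidin-1-yl and a 1.3-fold higher number from compound 2 to compound 4 (0.11 log units; within the scatter) against 4-chlorophenoxy. A third, sulfur-linked group thus joins these two at one level, and only 1H-pyrrol-1-yl stands apart, with a 13-fold lower number from compound 1 to compound 4 (1.10 log units; beyond the scatter) as the step away from it. Nothing shown explains this difference. Still open, from the compounds shown here alone, is whether an open-chain group here, such as dimethylamino, would stay at this level or fall nearer 1H-pyrrol-1-yl.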